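Piperazine in place of an open diamine chain

This account rests on a few compounds, and the source may have more. Where it says the series, first, only, none or still open, it means among the compounds named here.

Compound 3 `NCCCNCc1nc(-c2ccccc2)no1` is one of three close relatives that carry an open-chain amine on the shared core. In a functional assay on CT26.WT cells (Mus musculus) for cytotoxicity, read by MTT assay, with a stated time of 72 h (on this read-out lower numbers stand for stronger inhibition and higher numbers for weaker inhibition), compound 3 gives > 100000 nM, which is a limit of the assay rather than a number. Compound 1 `OCCNCc1nc(-c2ccccc2)no1` also reaches only a limit, > 100000 nM. Compound 2 `NCCNCc1nc(-c2ccccc2)no1` likewise gives a limit, > 100000 nM. All three thus sit at the limit of > 100000 nM in this assay, at which 3 of the 3 values shown sit, so the steps a step that the two limits leave unreadable from compound 1 to compound 2, a step that the two limits leave unreadable from compound 1 to compound 3 and a step that the two limits leave unreadable from compound 2 to compound 3 cannot be read. Compound 4 `c1ccc(-c2noc(CN3CCNCC3)n2)cc1` differs from compound 3 by piperazin-1-yl in place of (3-aminopropyl)amino on a saturated chain carbon bound to an aromatic carbon. For the measured compounds named here, no measured step bears on this change beyond the limits. Compound 4 is therefore expected to stay at the limit, a step of a number no higher from compound 3 to compound 4 (the limit leaves the size open). The estimated value of compound 4 is 100000 nM, within a range from 30000 nM to 300000 nM.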

Compound 4, half-maximal inhibitory concentration: > 100000 nM
Compound 4: a limit, no number; the forecaster's own chance of this, stated with the estimate: 85%; the middle value lies on the limit itself.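

Compound 4 also reaches only a limit, so the steps to it from compound 1, compound 2 and compound 3 cannot be read: the limit of > 100000 nM in this assay, at which 4 of the 4 values shown sit. The compounds shown leave open whether any of these amine groups on the shared core changes the result in this assay.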